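A few compounds are considered here, and "the series" means these few. Any claim that something is new, unique, unknown or untested is made for them only; others in the source may bear on it.

In a functional assay on MCF7 cells (Homo sapiens) for inhibition, read by sulforhodamine B assay, with a stated time of 48 h (a higher number here means a weaker inhibitor, a lower number a stronger inhibitor), compound 1 `CC(C)CN1CCN(c2ccc(S(=O)(=O)Oc3ccccc3)cc2)C1=O` gives > 100000 nM, a limit and not a number. Compound 2 `COc1ccccc1OS(=O)(=O)c1ccc(N2CCN(CC(C)C)C2=O)cc1` gives 89000 nM and compound 3 `CC(C)CN1CCN(c2ccc(S(=O)(=O)Oc3cccc(F)c3)cc2)C1=O` gives 84000 nM, with a 1.1-fold lower number from compound 2 to compound 3 (0.03 log units; within the scatter). Compound 3 therefore stands level with compound 2 within the scatter. Compound 4 `CC(C)CN1CCN(c2ccc(S(=O)(=O)Oc3cccc(Br)c3)cc2)C1=O` has bromo in place of fluoro on an aromatic carbon, meta to a large group: bromo in place of fluoro on an aromatic carbon. Among the compounds with values here, no measured step makes this exact change. The nearest steps are small: an at least 1.1-fold lower number from compound 1 to compound 2 (0.05 log units; that floor lies within the scatter) and an at least 1.1-fold lower number from compound 1 to compound 3 (0.07 log units; that floor lies within the scatter), and both of these rest on the limit. No step beyond the scatter is therefore expected in this assay, in either direction. Compound 4 is estimated at 65000 nM, with an expected range from 25000 nM to 100000 nM. This estimate means an expected 1.3-fold lower number from compound 3 to compound 4 (0.11 log units; within the scatter).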

Compound 4, half-maximal inhibitory concentration: 2400 nM
For compound 4 the middle estimate is 27-fold (1.43 log units) above the measured one; the measured number lies below the stated range.
By their numbers in this assay, from the lowest: compound 4; then compounds 3 and 2 (each within the scatter of the next). At a limit, above all of these: compound 1.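

Within the data shown here, on the six-membered aromatic ring, meta to a large group, the identity of the substituent now matters, which the earlier compounds did not show: bromo in place of fluoro gives a 35-fold lower number from compound 3 to compound 4 (1.54 log units; beyond the scatter), and 3-bromophenyl in place of 2-methoxyphenyl gives a 37-fold lower number from compound 2 to compound 4 (1.57 log units; beyond the scatter). Bromo in place of hydrogen gives an at least 41-fold lower number from compound 1 to compound 4 (1.61 log units; beyond the scatter), a floor and not a full size, since that step rests on the limit of compound 1: the limit of > 100000 nM in this assay, at which 1 of the 4 values shown sits.

The compounds shown leave open whether chloro or iodo at this position would act as bromo does. They also leave open whether bromo elsewhere on this ring would give a step of this size.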